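Trading One Five-Membered Ring for Another at the Amide

A few compounds are considered here, and "the series" means these few. Any claim that something is new, unique, unknown or untested is made for them only; others in the source may bear on it.

Three compounds share one core and differ only in the ring that hangs from a saturated chain carbon bound to a carbonyl carbon. In a functional assay on CHO-K1 cells for antagonist activity at C-X-C chemokine receptor type 3 (Homo sapiens), read by FLIPR, with a stated time of 10 min (on this read-out higher numbers stand for weaker inhibition and lower numbers for stronger inhibition), compound 1 `CCOc1ncc(-c2nc(C(F)(F)F)sc2N2CCN(C(=O)Cn3ccc4cccnc43)[C@H](C)C2)cn1` gives 3.8 nM, compound 2 `CCOc1ncc(-c2nc(C(F)(F)F)sc2N2CCN(C(=O)Cn3c(=O)oc4ccccc43)[C@H](C)C2)cn1` gives 3.3 nM, and compound 3 `CCOc1ncc(-c2nc(C(F)(F)F)sc2N2CCN(C(=O)Cn3nc(C)nc3C)[C@H](C)C2)cn1` gives 7 nM. Going by the values given here, compound 3 thus carries the highest of the three numbers, although the step of a 1.8-fold higher number from compound 1 to compound 3 (0.27 log units; within the scatter) stays inside the usual scatter and only the step of a 2.1-fold higher number from compound 2 to compound 3 (0.33 log units; beyond the scatter) passes it; the step of a 1.2-fold lower number from compound 1 to compound 2 (0.06 log units; within the scatter) is too small to count.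

Compound 4 `CCOc1ncc(-c2nc(C(F)(F)F)sc2N2CCN(C(=O)Cn3cc(Cl)cn3)[C@H](C)C2)cn1` introduces the change (4-chloro-1H-pyrazol-1-yl in place of 3,5-dimethyl-1H-1,2,4-triazol-1-yl on a saturated chain carbon bound to a carbonyl carbon). Each measured step sits at this same place, and each is small or at most modest, so swapping rings here has so far moved the number little in either direction. The same is expected of compound 4: the step of a 1.2-fold lower number from compound 3 to compound 4 (0.07 log units; within the scatter) from compound 3 to compound 4 is estimated to stay within or close to the scatter, with a slight pull toward a lower number given that the two neighbours of compound 3 both sit somewhat lower. Compound 4 is therefore expected to give about 6 nM in this assay, with a likely range from 2.5 nM to 15 nM.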

Compound 4, half-maximal inhibitory concentration: 5.1 nM
Beside the measured number, compound 4's estimate is 1.2-fold (0.07 log units) above it, and the stated range covers the measured number.
By their numbers in this assay, from the lowest: compounds 2, 1, 4 and 3 (each within the scatter of the next, the first and the last beyond it).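

In this assay, going by these compounds alone, the step of a 1.4-fold lower number from compound 3 to compound 4 (0.14 log units; within the scatter) shows that 4-chloro-1H-pyrazol-1-yl, the only group of the four that carries chlorine, can take the place of 3,5-dimethyl-1H-1,2,4-triazol-1-yl without a change beyond the scatter. This same single ring also stays within the scatter of both two-ring groups, with a 1.5-fold higher number from compound 2 to compound 4 (0.19 log units; within the scatter) and a 1.3-fold higher number from compound 1 to compound 4 (0.13 log units; within the scatter), so at this place a second ring is not needed to keep the number in this range, even though compound 3, also a single ring, lies beyond the scatter of compound 2. Nothing available explains why these different rings read so much alike.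

The compounds shown exchange the whole ring at once, which leaves the share of the chlorine alone an open question. As far as these compounds go, all four groups on the saturated chain carbon bound to a carbonyl carbon are aromatic rings, so how a carboxylic acid, a simple amine or a longer chain would read at this place also remains open.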